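The source may hold more compounds than are shown below. What is called first, only, known or untested is meant among the compounds shown, and "the series" means these compounds.

Notes on the series in an ADME assay on CCRF-CEM cells (Homo sapiens) for cytotoxicity; a lower number here means that less compound is tolerated, a higher number that more compound is tolerated. Compound 1 `O=C(NCCO)c1cnc2ccccc2c1Cl` gives > 100 uM, a limit of the assay. Compound 2 `O=C(NCCO)c1c[nH]c2ccc(Oc3ccccc3)cc2c1=O` gives > 100 uM, also a limit. Compound 3 `O=C(NCCO)c1c[nH]c2ccccc2c1=O` gives > 100 uM, again a limit. Among the measured compounds shown here, the only step between measured compounds that differ in one place, hydrogen in place of phenoxy on an aromatic carbon, is a step that the two limits leave unreadable from compound 2 to compound 3. Compound 3 thus stands at the limit of > 100 uM in this assay, at which 3 of the 3 values shown sit. Compound 4 `O=C(NCCO)c1c[nH]c2ccc(Cl)cc2c1=O` differs from compound 3 by chloro in place of hydrogen on an aromatic carbon. For the measured compounds named here, the one step available, a step that the two limits leave unreadable from compound 2 to compound 3, bears on this change only in that a far larger group at the same place left the limit intact. Compound 4 is therefore expected to remain near that limit, a step that the limit leaves unreadable from compound 3 to compound 4 giving an estimate of 150 uM within 50 uM to 400 uM.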

Compound 4, half-maximal toxic concentration: > 100 uM
Compound 4 was reported as a limit; the forecaster's own chance of this, stated with the estimate: 70%; the middle value does not contradict the limit.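

Among the compounds shown here, compound 4 also sits at a limit, so no step to it from compound 2 or compound 3 can be read. What concentration of any compound shown is toxic in this assay stays open, with every value at one point: the limit of > 100 uM in this assay, at which 4 of the 4 values shown sit.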